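This account rests on a few compounds, and the source may have more. Where it says the series, first, only, none or still open, it means among the compounds named here.

Compound 1, `CCOC(=O)c1c(C)noc1OCC(=O)[C@H](CC(=O)O)NC(=O)[C@@H](NC(=O)COc1cccc2ccccc12)C(C)C`, in a functional assay on Jurkat cells (Homo sapiens) for inhibition (a lower number here means a stronger inhibitor, a higher number a weaker inhibitor), gives > 200000 nM, a limit of the assay and not a number.
Compound 2, `CC(C)[C@H](NC(=O)COc1cccc2ccccc12)C(=O)N[C@@H](CC(=O)O)C(=O)CSc1nnnn1C`, in this assay gives > 200000 nM, again a limit.
Compound 3, `CC(C)[C@H](NC(=O)COc1cccc2ccccc12)C(=O)N[C@@H](CC(=O)O)C(=O)COc1cc(C(F)(F)F)ncn1`, in this assay gives > 200000 nM, again a limit.

All three compounds share the same core and differ only in the group carried on the carbon next to the ketone. None of them gave a readable number: the limit of > 200000 nM in this assay, at which 3 of the 3 values shown sit, describes where every value sits. Compound 3 therefore stands nowhere in particular among its neighbours; it is simply one of three compounds at the same limit. The steps between the measured compounds are all unreadable for that reason: a step that the two limits leave unreadable from compound 1 to compound 2, a step that the two limits leave unreadable from compound 1 to compound 3 and a step that the two limits leave unreadable from compound 2 to compound 3.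

Compound 4, `CC(C)[C@H](NC(=O)COc1cccc2ccccc12)C(=O)N[C@@H](CC(=O)O)C(=O)COc1nncc(Cl)c1Cl`, is the unmeasured compound. It differs from compound 3 in one place: 4,5-dichloropyridazin-3-yl in place of 6-(trifluoromethyl)pyrimidin-4-yl on an oxygen on a saturated carbon. Within the data shown here, each earlier exchange of the group at this position, whether between ring types or between oxygen and sulfur linkers, left the readout at the limit, so no measured step tells how large a change such an exchange can produce or in which direction. The expectation for compound 4 in this assay is a step that the limit leaves unreadable from compound 3 to compound 4, which means, most likely, another limit rather than a number. Compound 4 is estimated at 300000 nM, with a range from 50000 nM to 2000000 nM.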

Compound 4, half-maximal inhibitory concentration: > 200000 nM
Compound 4: no number, only a limit (the forecaster's own chance of this, stated with the estimate: 85%); the middle value does not contradict the limit.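

Compound 4 also stops at a limit of the assay rather than a number, so no step from compound 1, compound 2 or compound 3 to compound 4 can be read, and all four compounds sit together: the limit of > 200000 nM in this assay, at which 4 of the 4 values shown sit.

What the compounds shown leave open is whether any group at this position changes inhibition in this assay, and by how much.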